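The source may report more compounds than this note shows. Statements on the series, on what has been measured and on what is new or still open speak of the compounds shown alone.

Measured in a functional assay on MGC-803 cells (Homo sapiens) for inhibition, read by MTT assay, with a stated time of 72 h; a lower number here means a stronger inhibitor, a higher number a weaker inhibitor:
compound 1 `Cc1cc(Nc2cc(-c3ccccc3)[nH]n2)n2nc(SCc3ccc([N+](=O)[O-])cc3)nc2n1`: 4250 nM
compound 2 `Cc1cc(Nc2ccn(Cc3cccc4ccccc34)n2)n2nc(SCc3ccc(Br)cc3)nc2n1`: 3240 nM
compound 3 `Cc1cc(Nc2ccn(Cc3ccccc3)n2)n2nc(SCc3ccc(Br)cc3)nc2n1`: 4720 nM

Compound 1 does not separate from the other two. Its value lies within the scatter of both compound 2 and compound 3, so the three compounds sit at one level, with no meaningful order among them.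

Still unmeasured is compound 4 `Cc1cc(Nc2cc(-c3ccccc3)[nH]n2)n2nc(SCC(=O)c3ccccc3)nc2n1`, which keeps the core of compound 1 and alters only the group on a saturated chain carbon bound to a sulfur. The change is benzoyl in place of 4-nitrophenyl on a saturated chain carbon bound to a sulfur. Cut one bond further out, it reads 4-nitrobenzyl to benzoylmethyl.

Within the data shown here, the only measured step is a 1.5-fold higher number from compound 2 to compound 3 (0.16 log units; within the scatter), which lies within the scatter. It concerns another place, a saturated chain carbon bound to an aromatic nitrogen, so it bears on this change only indirectly. Among the measured compounds shown here, no measured pair tests a replacement of 4-nitrophenyl, and the series offers no evidence for a shift in either direction.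

No step beyond the scatter is therefore expected in this assay, and the estimated step is a 1.1-fold higher number from compound 1 to compound 4 (0.02 log units; within the scatter). Going by these compounds, the uncertainty stays wide, since this place is untested. Compound 4 is estimated at 4500 nM, with an expected range of 1500 nM to 13000 nM.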

Compound 4, half-maximal inhibitory concentration: 2580 nM
Beside the measured number, compound 4's estimate is 1.7-fold (0.24 log units) above it; measured number inside the range.
By their numbers in this assay, from the lowest: compounds 4, 2, 1 and 3 (each within the scatter of the next).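

In this assay, among these compounds, the replacement of 4-nitrophenyl by benzoyl on a saturated chain carbon bound to a sulfur gives a 1.6-fold lower number from compound 1 to compound 4 (0.22 log units; within the scatter) and is the first measured change at this place. Read one bond further out, 4-nitrobenzyl can give way to benzoylmethyl on the core of compound 1 without a step beyond the scatter, so this one replacement shows that the number holds at its level even though the group entering is not a nitro-bearing benzyl. Nothing available explains this result or links it to any feature of either group.

This single pair changes the carbonyl and the nitro group together, so it cannot show what either contributes alone, and an unsubstituted benzyl at this place would separate the two. Going by these compounds, it also remains open whether any group on this carbon can produce a step beyond the scatter, for example a carboxylic acid, an amine or a longer chain ending in a phenyl ring.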